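Swapping chloro for bromo on a shared core

The compounds below may be only part of what the source reports. "The series", "measured", "known", "first", "only" and "open" are said of these compounds alone.

Compound 1 `O=C1/C(=C/c2ccccc2Cl)CCc2c(O)cccc21` and compound 2 `O=C1/C(=C/c2ccccc2Br)CCc2c(O)cccc21` share one core; the change between them is bromo in place of chloro on an aromatic carbon. In a functional assay on RAW264.7 cells (Mus musculus) for inhibition (on this read-out lower numbers stand for stronger inhibition and higher numbers for weaker inhibition), compound 1 gives 1280 nM, and compound 2 gives 1240 nM, so that a 1.0-fold lower number from compound 1 to compound 2 (0.01 log units; within the scatter). Compound 3 `O=C1/C(=C/c2ccccc2Cl)CCc2ccc(O)cc21` carries the same atoms joined differently; the difference between the two cores is not broken down here. In this assay compound 3 gives 270 nM, the lowest of the three numbers. Compound 4 `O=C1/C(=C/c2ccccc2Br)CCc2ccc(O)cc21` is still unmeasured and differs from compound 3 by the same change, (bromo in place of chloro on an aromatic carbon). Because the earlier step of a 1.0-fold lower number from compound 1 to compound 2 (0.01 log units; within the scatter) stayed within the scatter, the step from compound 3 to compound 4 is expected to be a 1.0-fold lower number from compound 3 to compound 4 (0.02 log units; within the scatter). For compound 4 the estimated value is 260 nM, expected between 130 nM and 540 nM.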

Compound 4, half-maximal inhibitory concentration: 500 nM
For compound 4 the middle estimate is 1.9-fold (0.28 log units) below the measured one; measured number inside the range.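

Swapping chloro for bromo on the second core gives a 1.9-fold higher number from compound 3 to compound 4 (0.27 log units; within the scatter) in this assay. Set beside the earlier step, the swap reads alike on both cores as far as these numbers can tell: the same change on two cores in this assay, a 1.0-fold lower number (0.01 log units; within the scatter) from compound 1 to compound 2 and a 1.9-fold higher number (0.27 log units; within the scatter) from compound 3 to compound 4, 1.9-fold (0.28 log units) apart, within the scatter of two such steps This shows that, for these two cores, the swap carried over with no difference that can be told from the scatter, but it does not show that the two steps are identical or that a third core would behave the same way.

The compounds shown carry only chloro or bromo at this aromatic carbon. Going by these compounds, how a fluoro, a methoxy or a nitrile at the same carbon would read in this assay remains open.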